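The source may report more compounds than this note shows. Statements on the series, on what has been measured and on what is new or still open speak of the compounds shown alone.

Measured so far in a functional assay on SiHa cells (Homo sapiens) for inhibition, read by sulforhodamine B assay; on this read-out lower numbers stand for stronger inhibition of growth and higher numbers for weaker inhibition of growth:
compound 1 `c1ccc(-c2ccc(-c3ccc(-c4nc5ccccc5[nH]4)cc3)cc2)cc1` gives 100000 nM
compound 2 `Cc1ccc2[nH]c(-c3ccc(-c4ccc(-c5ccc(N(C)C)cc5)cc4)cc3)nc2c1` gives 7110 nM
compound 3 `Cc1ccc2[nH]c(-c3ccc(-c4ccc(-c5cccc(Cl)c5)cc4)cc3)nc2c1` gives 3600 nM

Compound 3 carries the lowest number of the three in this assay. Its nearest neighbour is compound 2, separated by a 2.0-fold lower number from compound 2 to compound 3 (0.30 log units; within the scatter), so the two are not distinguishable here. Compound 1 sits far higher, a gap that is beyond the scatter, but compound 1 differs from compound 3 in two places at once, on the core and on the terminal ring, so its value cannot be assigned to either change alone.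

Compound 4 `Cc1ccc2[nH]c(-c3ccc(-c4ccc(-c5ccccc5)cc4)cc3)nc2c1` is the next step from compound 3: hydrogen in place of chloro on an aromatic carbon. Going by the values given here, no measured pair shows the removal of a chloro group on its own. Among the compounds with values here, the only single step available, the swap of 4-(dimethylamino)phenyl for 3-chlorophenyl, stayed within the scatter and does not directly address an unsubstituted terminal ring. Within the data shown here, the one compound with an unsubstituted terminal ring, compound 1, gives 100000 nM, but with the core difference confounding it.

Compound 4 is therefore expected to move upward from compound 3 by a 4.2-fold higher number from compound 3 to compound 4 (0.62 log units; beyond the scatter), a loss of moderate size and of uncertain extent. The estimate for compound 4 in this assay is 15000 nM, within 4000 nM to 60000 nM.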

Compound 4, concentration for 50% growth inhibition: 35200 nM
Compound 4: the middle estimate sits 2.3-fold (0.37 log units) below what was measured; measured number inside the range.
By their numbers in this assay, from the lowest: compounds 3 and 2 (each within the scatter of the next); then compound 4; then compound 1.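

In this assay, taking chloro off the terminal ring gives a 9.8-fold higher number from compound 3 to compound 4 (0.99 log units; beyond the scatter) as a clean single change, so the group at this aromatic carbon counts for growth inhibition. The dimethylamino group on the terminal ring shows the same direction, with a 5.0-fold higher number from compound 2 to compound 4 (0.69 log units; beyond the scatter) on its replacement by hydrogen, so here both substituted rings carry lower numbers than the unsubstituted phenyl. The methyl on the shared core also separates out, with a 2.8-fold lower number from compound 1 to compound 4 (0.45 log units; beyond the scatter) in its favour, and the high number of compound 1 is no longer an unresolved mix of two changes.

The compounds shown offer no measurement that explains any of these steps. Open questions are whether a methoxy group, an amine or a carboxylic acid on the terminal ring would match chloro, and whether the methyl step holds with chloro present.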